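Working notes on cytotoxicity across a fluorinated ether series

The compounds below may be only part of what the source reports. "The series", "measured", "known", "first", "only" and "open" are said of these compounds alone.

Measured so far:
compound 1 `Cc1c(-c2ccc(Cc3ccc(C(C)(C)C)cc3)cc2)[nH]c2cccc(F)c2c1=O`: > 5000 nM
compound 2 `Cc1c(-c2ccc(Cc3ccc(OCC(F)(F)F)cc3)cc2)[nH]c2cccc(F)c2c1=O`: > 5000 nM

In an ADME assay on Huh7.5.1 cells (Homo sapiens) for cytotoxicity, read by WST assay, with a stated time of 48 h (on this read-out higher numbers stand for lower toxicity in this test and lower numbers for higher toxicity in this test), compound 1 gives > 5000 nM, which is a limit of the assay rather than a number. In this assay compound 2 gives > 5000 nM, again a limit. Among the compounds with values here, compound 2 thus stands at the limit of > 5000 nM in this assay, at which 2 of the 2 values shown sit, and the one measured step, a step that the two limits leave unreadable from compound 1 to compound 2, cannot be sized from these two limits. Compound 3 `Cc1c(-c2ccc(Cc3ccc(OC(F)F)cc3)cc2)[nH]c2cccc(F)c2c1=O` differs from compound 2 by difluoromethyl in place of 2,2,2-trifluoroethyl on an oxygen on an aromatic ring. Within the data shown here, the only step that bears on this change is a step that the two limits leave unreadable from compound 1 to compound 2, and it is unreadable, so no direction is given for this assay; the expectation is no step beyond the scatter, with compound 3 most likely returning a limit as well. For compound 3 in this assay the estimate is 8000 nM, within 4000 nM to 20000 nM, a step that the limit leaves unreadable from compound 2 to compound 3 expected to lie within the scatter.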

Compound 3, half-maximal cytotoxic concentration: > 5000 nM
Compound 3: a limit, no number; the forecaster's own chance of this, stated with the estimate: 80%; the middle value is on the limit's open side.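

Compound 3 in this assay returns a limit, as compound 1 and compound 2 do, so no step among these three compounds can be read: the limit of > 5000 nM in this assay, at which 3 of the 3 values shown sit. The compounds shown leave open how far each true cytotoxic concentration lies past that limit, and whether the three differ at all.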